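Thioester to cyclohexyl ester on the shared core

A few compounds are considered here, and "the series" means these few. Any claim that something is new, unique, unknown or untested is made for them only; others in the source may bear on it.

Of the compounds shown here, three with the same core have been measured in an assay on membranes from HeLa cells for displacement of a labelled ligand from adenosine receptor A3 (Homo sapiens), read by scintillation counting, with a stated time of 180 min, tested at 1 uM; on this read-out higher numbers stand for more inhibition at the one concentration tested (going by the name of the read-out) and lower numbers for less inhibition. Compound 1 `CC1=C(C(=O)OCc2ccccc2)C(c2ccoc2)NC(=O)N1` gives 1%, compound 2 `CC1=C(C(=O)CC(C)C)C(c2ccoc2)NC(=O)N1` gives 18%, and compound 3 `CCSC(=O)C1=C(C)NC(=O)NC1c1ccoc1` gives 1%. Within the data shown here, compound 3 thus stands level with compound 1 and, together with it, at the bottom of the three numbers; the only step measured, a number 17 percentage points lower from compound 2 to compound 3 (beyond the scatter), shows a modest drop. Compound 4 `CC1=C(C(=O)OC2CCCCC2)C(c2ccoc2)NC(=O)N1` differs from compound 3 by cyclohexyloxy in place of ethylsulfanyl on a carbonyl carbon. Among the measured compounds shown here, no measured step covers this exact change, but compound 1, which also carries an ester, gives 1%. Compound 4 is therefore expected to stay low, a step of a number 4 percentage points higher from compound 3 to compound 4 (within the scatter) within the scatter, at an estimated 5% with a range from 0% to 20%.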

Compound 4, a percentage reported as inhibition, at one concentration (the size of the read-out at that concentration, not a potency): 1%
Estimate against measurement, compound 4: 4 percentage points above; measured number inside the range.
By their numbers in this assay, from the lowest: compounds 1, 3 and 4 (each within the scatter of the next); then compound 2.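

Cyclohexyloxy in place of ethylsulfanyl on this carbonyl carbon gives no change at the digits printed from compound 3 to compound 4 (within the scatter) in this assay, so a larger group carrying a ring does not shift the reading. Cyclohexyl in place of benzyl on the ester oxygen likewise gives no change at the digits printed from compound 1 to compound 4 (within the scatter), which shows that a ring without aromatic character reads the same here. Cyclohexyloxy in place of isobutyl gives a number 17 percentage points lower from compound 2 to compound 4 (beyond the scatter), so a second ester now sits apart from compound 2. On these data alone, whether an amine or a longer carbon chain on this carbonyl carbon would raise the number remains open. Nothing available explains why compound 2 stands apart.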